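The source may hold more compounds than are shown below. What is called first, only, known or untested is meant among the compounds shown, and "the series" means these compounds.

Of the compounds shown here, three have so far been measured in an ADME assay on a cell-free system (plasma, Macaca mulatta) for metabolic stability, read by LC-MS, with a stated time of 60 min, tested at 10 uM; on this read-out lower numbers stand for a less stable compound and higher numbers for a more stable compound. Compound 3 `COC(=O)[C@H](CCC(=O)C=[N+]=[N-])NC(=O)OC(OC(=O)C(C)(C)C)C(C)C` gives 61%, and compound 2 `CCC(OC(=O)N[C@@H](CCC(=O)C=[N+]=[N-])C(=O)OC)OC(=O)C(C)(C)C` gives 75%. These two differ in one place only, (hydrogen in place of methyl on a saturated chain carbon bound to two saturated chain carbons), and that change made a step of a number 14 percentage points higher from compound 3 to compound 2 (beyond the scatter). Compound 1 `CC(C)[C@H](N)C(=O)N[C@@H](CCC(=O)C=[N+]=[N-])C(=O)OCc1c[nH]c2ccccc12` gives 10% in this assay, the lowest of the three numbers, lying well apart from both compound 3 and compound 2. The difference between the core of compound 1 and the core of compound 3 is not broken down here.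

Compound 4 `CC[C@H](N)C(=O)N[C@@H](CCC(=O)C=[N+]=[N-])C(=O)OCc1c[nH]c2ccccc12` has not yet been measured. It differs from compound 1 by hydrogen in place of methyl on a saturated chain carbon bound to two saturated chain carbons, which is the same change that was made from compound 3 to compound 2. On that basis, a step of similar size and the same direction is expected, so that compound 4 is estimated to move by a number 12 percentage points higher from compound 1 to compound 4 (beyond the scatter) in this assay. Within the data shown here, the expectation rests on the single measured instance of this change, a number 14 percentage points higher from compound 3 to compound 2 (beyond the scatter), while the core of compound 1 is different from that of compound 3, which makes the transfer uncertain. The value expected for compound 4 is 22%, within a range from 6% to 45%.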

Compound 4, percent of the compound remaining: 4%
Compound 4: the middle estimate sits 18 percentage points above what was measured; the whole stated range lies above it.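

Replacing isopropyl with ethyl on the core of compound 1 gave a step of a number 6 percentage points lower from compound 1 to compound 4 (within the scatter) in this assay, so this pair shows no change that can be told apart from the scatter. Set beside the earlier step, the same change did not carry over from one core to the other: the same change on two cores in this assay, a number 14 percentage points higher (beyond the scatter) from compound 3 to compound 2 and a number 6 percentage points lower (within the scatter) from compound 1 to compound 4, 20 percentage points apart, beyond the scatter of two such steps. Among these compounds, with only one pair on each core, this shows that the step on one core was no guide to the step on the other, but it does not show which part of the cores sets them apart, or how the change would behave on a third core.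

The compounds shown leave open how a longer chain, such as butyl, or a phenyl group in the place of this chain would read on either core. They also leave open whether a second pair on each core would repeat the two steps seen so far.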